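The compounds below may be only part of what the source reports. "The series", "measured", "known", "first", "only" and "open" are said of these compounds alone.

In a functional assay on HT-29 cells (Homo sapiens) for cytotoxicity, read by sulforhodamine B assay (a higher number here means a weaker inhibitor of growth, a lower number a stronger inhibitor of growth), compound 1 `CC1=CC[C@@H]([C@@](C)(O)CCCC(C)(C)NC(=S)NN)CC1` gives > 100000 nM, which is a limit of the assay and not a number. Compound 2 `COc1ccc(/C=N\NC(=S)NC(C)(C)CCC[C@](C)(O)[C@@H]2CC=C(C)CC2)cc1` gives 35200 nM. Compound 3 `CC1=CC[C@@H]([C@@](C)(O)CCCC(C)(C)NC(=S)N/N=C\c2ccccc2[N+](=O)[O-])CC1` gives 16800 nM, the lower of the two true numbers so far, so it is the best starting point on the data shown, though still a weak growth inhibitor in absolute terms.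

Compound 4 `CC1=CC[C@@H]([C@@](C)(O)CCCC(C)(C)NC(=S)N/N=C\c2cccc(Cl)c2)CC1` differs from compound 3 in one group: 3-chlorophenyl in place of 2-nitrophenyl on a carbon with a double bond to nitrogen. In words, 3-chlorophenyl stands in place of 2-nitrophenyl on a carbon with a double bond to nitrogen, and one six-membered aromatic ring of carbon only is present on both sides of the swap.

Within the data shown here, two measured steps bear on this change. The closer one is a 2.1-fold lower number from compound 2 to compound 3 (0.32 log units; beyond the scatter), a swap of one substituted phenyl for another at this same place, and it was modest. The other, an at least 2.8-fold lower number from compound 1 to compound 2 (0.45 log units; beyond the scatter), brought in an aromatic ring, and compound 4 keeps such a ring. A swap of this kind has so far moved the number only a little, so no large change is expected in this assay, and the direction is uncertain. The estimated result is a 1.2-fold higher number from compound 3 to compound 4 (0.08 log units; within the scatter), which would most likely stay close to the scatter. For compound 4 the expected value is 20000 nM, with an estimated range of 8000 nM to 50000 nM.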

Compound 4, concentration for total growth inhibition: 16500 nM
For compound 4 the middle estimate is 1.2-fold (0.08 log units) above the measured one; the range from low to high includes it.
By their numbers in this assay, from the lowest: compounds 4 and 3 (each within the scatter of the next); then compound 2. At a limit, above all of these: compound 1.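

In this assay, the step of a 1.0-fold lower number from compound 3 to compound 4 (0.01 log units; within the scatter) shows that 3-chlorophenyl and 2-nitrophenyl cannot be told apart at this position, so the nitrogen and oxygen atoms of the nitro group are not needed to reach this level of growth inhibition. Among these compounds, the step of a 2.1-fold lower number from compound 2 to compound 4 (0.33 log units; beyond the scatter) closely matches the one already seen for compound 3, which leaves compound 2, with its 4-methoxyphenyl, as the one of the three aryl compounds set apart from the other two, although the gap remains modest. The step of an at least 6.0-fold lower number from compound 1 to compound 4 (0.78 log units; beyond the scatter) brings in the aromatic ring, but its true size is unknown, as compound 1 is held at a limit and not a number: the limit of > 100000 nM in this assay, at which 1 of the 4 values shown sits.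

These compounds leave open whether an aromatic ring of carbon only is needed on the carbon with a double bond to nitrogen, or whether a pyridine ring or a cyclohexyl ring would serve equally well. They also leave open how an amine or a carboxylic acid on the phenyl ring would move the number, and whether any such change could take growth inhibition far beyond the narrow span seen here.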